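The source may hold more compounds than are shown below. What is called first, only, known or untested is meant among the compounds shown, and "the series" means these compounds.

Compound 1, `O=C(/C=C\Nc1ccc(Cl)cc1)c1nc(-c2ccc(C(F)(F)F)cc2)n2ccccc12`: in a functional assay on HCT-116 cells (Homo sapiens) for cytotoxicity, read by MTT assay, with a stated time of 48 h (on this read-out higher numbers stand for weaker inhibition and lower numbers for stronger inhibition), compound 1 gives 11500 nM.
Compound 2, `O=C(/C=C\Nc1ccc(F)cc1)c1nc(-c2ccc(C(F)(F)F)cc2)n2ccccc12`: in this assay compound 2 gives > 30000 nM, which is a limit of the assay and not a number.

Compound 2 therefore stands at the limit of > 30000 nM in this assay, at which 1 of the 2 values shown sits, so only a one-sided bound is known for it. Compound 3, `COc1ccc(N/C=C\C(=O)c2nc(-c3ccc(C(F)(F)F)cc3)n3ccccc23)cc1`, differs from compound 2 by methoxy in place of fluoro on an aromatic carbon. Going by the values given here, the single measured step, an at least 2.6-fold higher number from compound 1 to compound 2 (0.41 log units; beyond the scatter), concerns a different exchange, chloro for fluoro, and gives no direct reading on methoxy; it does show that a change at this position can move the number by at least that much. With compound 2 known only as a limit, the size and direction of the step to compound 3 cannot be fixed from these data, and the change an at least 1.5-fold lower number from compound 2 to compound 3 (0.17 log units; that floor lies within the scatter) is expected to remain within the scatter or modest. Compound 3 is estimated at 20000 nM, with a range from 6000 nM to 60000 nM.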

Compound 3, half-maximal inhibitory concentration: 7720 nM
Estimate against measurement, compound 3: 2.6-fold (0.41 log units) above, within the range that was stated.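

In this assay, the exchange to the 4-methoxyphenyl group shows that the group at this place can move the read-out toward stronger inhibition relative to fluoro: an at least 3.8-fold lower number from compound 2 to compound 3 (0.58 log units; beyond the scatter). This step is only a floor, because compound 2 is held at a limit of the assay and not at a number: the limit of > 30000 nM in this assay, at which 1 of the 3 values shown sits. Chloro and methoxy, by contrast, are not separated at this place, a 1.5-fold lower number from compound 1 to compound 3 (0.17 log units; within the scatter), so among the three compounds shown it is fluoro that stands apart from the other two.

The compounds shown leave open how far compound 2 truly lies from the other two, since its limit gives one side only. They also leave open whether an amine, a methyl group or a bare hydrogen at this place would read like fluoro or like chloro and methoxy.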